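Aryl amide swap in a cytotoxicity series

The compounds below may be only part of what the source reports. "The series", "measured", "known", "first", "only" and "open" are said of these compounds alone.

Measured compounds:
- compound 1 `O=S(=O)(NCCCNc1nccc(-c2c(-c3cccc(F)c3)nc3sccn23)n1)c1ccc(Br)cc1`: 9400 nM
- compound 2 `O=S(=O)(NCCCNc1nccc(-c2c(-c3cccc(F)c3)nc3sccn23)n1)c1ccc(F)cc1`: > 20000 nM
- compound 3 `O=C(NCCNc1nccc(-c2c(-c3cccc(F)c3)nc3sccn23)n1)c1c(F)cccc1F`: 11400 nM

Compound 3 is a carbonyl-linked analogue of the shared core. In a functional assay on SK-MEL-28 cells (Homo sapiens) for cytotoxicity, read by MTT assay (on this read-out lower numbers stand for stronger inhibition and higher numbers for weaker inhibition), compound 3 gives 11400 nM, the highest of the two numbers that are not limits. Its nearest neighbour is compound 1, whose value in this assay is 9400 nM, and the step of a 1.2-fold higher number from compound 1 to compound 3 (0.08 log units; within the scatter) lies within the scatter. For compound 2 the read-out in this assay is a limit, > 20000 nM, as recorded in the limit of > 20000 nM in this assay, at which 1 of the 3 values shown sits. Compound 4 `Cc1ccc(C(=O)NCCNc2nccc(-c3c(-c4cccc(F)c4)nc4sccn34)n2)cc1` has not been measured; it differs from compound 3 by 4-methylphenyl in place of 2,6-difluorophenyl on a carbonyl carbon.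

Going by the values given here, no measured step touches the aryl group on the carbonyl carbon. The only ring substitution on record, an at least 2.1-fold higher number from compound 1 to compound 2 (0.32 log units; beyond the scatter), concerns the sulfonyl series and is at least modest. One therefore expects the step from compound 3 to compound 4 to be small, a 1.1-fold higher number from compound 3 to compound 4 (0.06 log units; within the scatter), without a clear direction beyond the scatter. Compound 4 is estimated at 13000 nM, within 6000 nM to 30000 nM.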

Compound 4, half-maximal inhibitory concentration: 18800 nM
Compound 4: middle estimate off by 1.4-fold (0.16 log units), on the low side; the measured number falls inside the stated range.
By their numbers in this assay, from the lowest: compounds 1, 3 and 4 (each within the scatter of the next). At a limit, above all of these: compound 2.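

Going by these compounds alone, at this position, the first measured change of aryl group on the carbonyl carbon, 4-methylphenyl in place of 2,6-difluorophenyl, gives in this assay a 1.6-fold higher number from compound 3 to compound 4 (0.22 log units; within the scatter), which is no clear difference. The wider change of the whole side chain from the bromo sulfonyl series also stays within the scatter, with a 2.0-fold higher number from compound 1 to compound 4 (0.30 log units; within the scatter). One further step starts from a limit and gives only a floor: an at least 1.0-fold lower number from compound 2 to compound 4 (0.02 log units; that floor lies within the scatter). Compound 2 stands at a limit: the limit of > 20000 nM in this assay, at which 1 of the 4 values shown sits.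

From the compounds shown here alone, whether an amine, a carboxylic acid or a pyridine ring in this place, or a longer chain before the carbonyl, would move the number beyond the scatter remains open. The compounds shown also do not separate any contribution of the methyl group from that of the two fluorine atoms it replaces.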